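Swapping the side group on compound 3

The compounds below may be only part of what the source reports. "The series", "measured", "known", "first", "only" and "open" are said of these compounds alone.

Compound 1 `COc1ccc(/C=C\c2cc(OC)c(OC)c(OC)c2)cc1OCc1ccc(CNC(C)(C)C(=O)O)cc1`: > 50000 nM (a limit)
Compound 2 `COc1ccc(/C=C\c2cc(OC)c(OC)c(OC)c2)cc1OCc1ccc(CN2CCCCC2C(=O)O)cc1`: > 50000 nM (a limit)
Compound 3 `COc1ccc(/C=C\c2cc(OC)c(OC)c(OC)c2)cc1OCc1ccc(CN2CC[C@@H](O)C2)cc1`: 53000 nM

Among the measured compounds shown here, in an ADME assay on NCM460 cells (Homo sapiens) for cytotoxicity, read by CCK-8 assay, with a stated time of 48 h (a lower number here means a stronger inhibitor, a higher number a weaker inhibitor), compound 3 gives 53000 nM, the only true number here. The other two results are limits, as the limit of > 50000 nM in this assay, at which 2 of the 3 values shown sit, shows. Compound 4 `COc1ccc(/C=C\c2cc(OC)c(OC)c(OC)c2)cc1OCc1ccc(CN2CCCCC2C(=O)NCCN)cc1` changes the side group of compound 3: 2-((2-aminoethyl)carbamoyl)piperidin-1-yl in place of 3-hydroxypyrrolidin-1-yl on a saturated chain carbon bound to an aromatic carbon. Compound 2, with 2-carboxypiperidin-1-yl, carries the closest group to the one entering. Still, a step that the limit leaves unreadable from compound 2 to compound 3 gives no size, and a step that the limit leaves unreadable from compound 1 to compound 3 gives none either. No step beyond the usual scatter, in either direction, is therefore expected in this assay. The expected change is a 1.3-fold lower number from compound 3 to compound 4 (0.12 log units; within the scatter). Compound 4 is estimated at 40000 nM, with an expected range from 15000 nM to 80000 nM.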

Compound 4, half-maximal inhibitory concentration: > 50000 nM
Compound 4 gave a limit, no number (the forecaster's own chance of this, stated with the estimate: 35%); middle value at least 1.2-fold (0.09 log units) away from the limit.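

Compound 4 gives > 50000 nM, a limit and not a number. No step to compound 4 from compound 1, compound 2 or compound 3 can be read, because the results stop at a shared limit: the limit of > 50000 nM in this assay, at which 3 of the 4 values shown sit.

The compounds shown leave open how compound 1, compound 2 and compound 4 compare with each other and with compound 3.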